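Methoxy Replaces Pyrrolidinyl on a Prostaglandin D2 Antagonist Series

The source may report more compounds than this note shows. Statements on the series, on what has been measured and on what is new or still open speak of the compounds shown alone.

Three compounds have been measured in an in vitro functional assay on HEK285-7 cells for antagonist activity at prostaglandin D2 receptor 2 (Homo sapiens), read by BRET and beta-arrestin recruitment; on this read-out higher numbers stand for larger maximal responses and lower numbers for smaller maximal responses:

Compound 1 `N#Cc1cc(-c2nc(C(c3ccc(F)cc3)c3ccc(F)cc3)sc2CC(=O)O)ccc1F` gives 80%
Compound 2 `O=C(O)Cc1sc(C(c2ccc(F)cc2)c2ccc(F)cc2)nc1-c1ccnc(N2CCC2)c1` gives 80%
Compound 3 `O=C(O)Cc1sc(C(c2ccc(F)cc2)c2ccc(F)cc2)nc1-c1ccnc(N2CCCC2)c1` gives 80%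

Compound 3 stands level with both neighbours. Its nearest comparator is compound 1, since no change at the digits printed from compound 1 to compound 3 (within the scatter), and compound 2 is no further away, since no change at the digits printed from compound 2 to compound 3 (within the scatter). Likewise no change at the digits printed from compound 1 to compound 2 (within the scatter). Across all three, exchanging the whole aryl group or only the amine on the pyridine left the maximal response where it was.

Compound 4 `COc1cc(-c2nc(C(c3ccc(F)cc3)c3ccc(F)cc3)sc2CC(=O)O)ccn1` is now to be measured. methoxy in place of pyrrolidin-1-yl on an aromatic carbon

The step that bears most directly on this change is the one at the same position, from compound 2 to compound 3, where no change at the digits printed from compound 2 to compound 3 (within the scatter). The larger swaps from compound 1 to compound 2 and to compound 3 also stayed within the scatter. Nothing measured here suggests that a smaller group on the pyridine would move the efficacy, so the step from compound 3 to compound 4 is expected to be no change at the digits printed from compound 3 to compound 4 (within the scatter), with no change beyond the scatter. Compound 4 is therefore estimated at 80%, with a range from 68% to 90%.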

Compound 4, largest response reached (reported as efficacy), in percent of the reference or control that the assay uses: 60%
Estimate against measurement, compound 4: 20 percentage points above; measured number outside the range, below it.
By their numbers in this assay, from the lowest: compound 4; then compounds 1, 2 and 3 (each within the scatter of the next).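

In this assay, going by these compounds alone, the carbon next to the ring nitrogen of the pyridine turns out to tolerate less than the earlier compounds suggested: azetidin-1-yl and pyrrolidin-1-yl were interchangeable there, but putting methoxy in place of pyrrolidin-1-yl gives a number 20 percentage points lower from compound 3 to compound 4 (beyond the scatter), and putting it in place of azetidin-1-yl gives a number 20 percentage points lower from compound 2 to compound 4 (beyond the scatter). The whole-group comparison agrees, since 2-methoxypyridin-4-yl in place of 3-cyano-4-fluorophenyl gives a number 20 percentage points lower from compound 1 to compound 4 (beyond the scatter), so the two amine-bearing pyridines match the 3-cyano-4-fluorophenyl group on this read-out, whereas the methoxy-bearing pyridine does not. No independent measurement is available that bears on the reason for this drop.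

The compounds shown do not separate the loss of the ring from the exchange of the amine nitrogen for an ether oxygen, as methoxy differs from both ring amines in these two respects at once. Dimethylamino, an open-chain amine, and ethoxy, a longer ether, on the same carbon would be the groups to tell these two differences apart, and how either would fare remains open.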